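The source may report more compounds than this note shows. Statements on the series, on what has been measured and on what is new or still open speak of the compounds shown alone.

Compound 1 `Cc1ccc(-c2c3c(nc(C)c2[C@H](OC(C)(C)C)C(=O)O)CCN(c2ccc(-c4ccccc4)cc2)C3)cc1` was examined in an ADME assay on MT2 cells (Homo sapiens) for cytotoxicity, read by XTT assay, with a stated time of 4 days; a higher number here means that more compound is tolerated, a lower number that less compound is tolerated. In this assay compound 1 gives > 40000 nM, which is a limit of the assay rather than a number. Compound 2 `Cc1ccc(-c2c3c(nc(C)c2C(OC(C)(C)C)C(=O)O)CCN(Cc2ccccc2-c2ccccc2)C3)cc1` was examined there as well. In this assay compound 2 gives > 40000 nM, again a limit and not a number. Compound 1 therefore stands at the limit of > 40000 nM in this assay, at which 2 of the 2 values shown sit, so the numbers shown do not separate it from compound 2. Compound 3 `Cc1ccc(-c2c3c(nc(C)c2[C@H](OC(C)(C)C)C(=O)O)CCN(C/C=C/c2ccccc2)C3)cc1` differs from compound 1 in one place: 3-phenylprop-2-en-1-yl in place of 4-phenylphenyl on an amine nitrogen in a ring. Within the data shown here, no step between two measured compounds covers such a change, so there is no measured guide for it. Nothing in the shown values points to a shift in this assay beyond the scatter. The expected step is a number no higher from compound 1 to compound 3 (the limit leaves the size open), none beyond the scatter. Compound 3 is estimated to give about 40000 nM in this assay, within a range from 15000 nM to 100000 nM, most likely reported again as a limit.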

Compound 3, half-maximal cytotoxic concentration: > 40000 nM
Compound 3 gave a limit, no number; the forecaster's own chance of this, stated with the estimate: 80%; the middle value lies on the limit itself.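

In this assay compound 3 gives > 40000 nM, a limit and not a number, so no step can be read between compound 1 and compound 3: the limit of > 40000 nM in this assay, at which 3 of the 3 values shown sit.

The compounds shown leave open where the half-maximal cytotoxic concentration of each lies, and whether 3-phenylprop-2-en-1-yl in place of 4-phenylphenyl changes it at all.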